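Removing a Chloro Group from a Purine-Like Core

A few compounds are considered here, and "the series" means these few. Any claim that something is new, unique, unknown or untested is made for them only; others in the source may bear on it.

Of the compounds shown here, two have been measured in a functional assay on OVCAR-8 cells (Homo sapiens) for cytotoxicity, read by sulforhodamine B assay, with a stated time of 48 h; on this read-out lower numbers stand for stronger inhibition of growth and higher numbers for weaker inhibition of growth. Compound 1 `Nc1nc(Cl)c2ncn(Cc3ccccc3CCl)c2n1` gives 19500 nM. Compound 2 `ClCc1ccccc1Cn1cnc2nc(Cl)nc(Cl)c21` gives 7070 nM, the lowest of the two numbers; its nearest neighbour is compound 1, which sits beyond the scatter with a higher number. The two differ in more than one place, so nothing is made of the gap beyond what the numbers show.

Compound 3 `ClCc1ccccc1Cn1cnc2ncnc(Cl)c21` has not been measured. It differs from compound 2 in one place: hydrogen in place of chloro on an aromatic carbon. For the measured compounds named here, no measured pair shows this change, so its effect is uncertain. Going by the values given here, the expected step of a 1.7-fold higher number from compound 2 to compound 3 (0.23 log units; within the scatter) is a small loss of potency, possibly none beyond the scatter, because the change leaves only a single chlorine of the compound 2 structure that gave 7070 nM. Compound 3 is therefore expected to give about 12000 nM, with a likely range from 5000 nM to 30000 nM.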

Compound 3, concentration for total growth inhibition: 8700 nM
Compound 3: middle estimate off by 1.4-fold (0.14 log units), on the high side; low and high end bracket the measured number.
By their numbers in this assay, from the lowest: compounds 2 and 3 (each within the scatter of the next); then compound 1.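

Placing hydrogen instead of chloro on this aromatic carbon, between two ring nitrogen atoms, gives a 1.2-fold higher number from compound 2 to compound 3 (0.09 log units; within the scatter) in this assay. For the compounds shown here, this is the first measured view of this single change, and it shows that the read-out does not separate the compound with chloro at this position from the one with hydrogen, so a chloro group on this carbon is not required for activity at this level. Nothing shown explains why the two compounds read alike.

Going by these compounds, whether a methoxy group or a carboxylic acid on this same carbon would give a similar number remains open. Also open is what the other ring chloro group contributes, as every compound shown carries it.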